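A few compounds are considered here, and "the series" means these few. Any claim that something is new, unique, unknown or untested is made for them only; others in the source may bear on it.

Measured in a functional assay on PC-3 cells (Homo sapiens) for inhibition, read by MTT assay; a higher number here means a weaker inhibitor, a lower number a stronger inhibitor:
- compound 1 `COc1c(N2CCN(C)CC2)c(F)cc2c(=O)c(C(=O)N/N=C\c3c(Cl)cccc3Cl)cn(C3CC3)c12`: 4.9 ug/mL
- compound 2 `COc1c(N2CCN(C)CC2)c(F)cc2c(=O)c(C(=O)N/N=C\c3ccc([N+](=O)[O-])cc3)cn(C3CC3)c12`: 15 ug/mL

Compound 2 gives the higher number of the two. Compound 3 `COc1cc(/C=N\NC(=O)c2cn(C3CC3)c3c(OC)c(N4CCN(C)CC4)c(F)cc3c2=O)cc(OC)c1OC` differs from it by 3,4,5-trimethoxyphenyl in place of 4-nitrophenyl on a carbon with a double bond to nitrogen, with 3,4,5-trimethoxyphenyl in place of 4-nitrophenyl. Going by the values given here, the one measured step at this place is modest: a 3.1-fold higher number from compound 1 to compound 2 (0.49 log units; beyond the scatter). Among the compounds with values here, no measured step covers the entering group, so the direction is open. A modest step at most is expected in this assay, leaning slightly towards a lower number, as compound 2 at 15 ug/mL is the top of the range so far. The expected step is a 1.5-fold lower number from compound 2 to compound 3 (0.18 log units; within the scatter). Compound 3 is estimated at 10 ug/mL, with an expected range of 3.5 ug/mL to 30 ug/mL.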

Compound 3, half-maximal inhibitory concentration: 8.5 ug/mL
Compound 3: middle estimate off by 1.2-fold (0.07 log units), on the high side; low and high end bracket the measured number.
By their numbers in this assay, from the lowest: compounds 1, 3 and 2 (each within the scatter of the next, the first and the last beyond it).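

In this assay the 3,4,5-trimethoxyphenyl group on a carbon with a double bond to nitrogen lies within the scatter of both other groups (a 1.8-fold lower number from compound 2 to compound 3 (0.25 log units; within the scatter); a 1.7-fold higher number from compound 1 to compound 3 (0.24 log units; within the scatter)). This position therefore accepts a group with more heavy atoms than 4-nitrophenyl without a step beyond the scatter, and compound 3 does not separate from either neighbour. Nothing available explains these numbers.

On these data alone, whether an amine or a carboxylic acid on this phenyl ring would stay within this narrow range remains open. So does the replacement of the phenyl ring by a saturated ring such as cyclohexyl.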